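The source may report more compounds than this note shows. Statements on the series, on what has been measured and on what is new or still open speak of the compounds shown alone.

Of the compounds shown here, three have been measured in a functional assay on CHO-K1 cells for agonist activity at Glucose-dependent insulinotropic receptor (Homo sapiens), read by a luciferase reporter, with a stated time of 5 h; a lower number here means that less compound is needed, a higher number that more compound is needed for the effect. Compound 1 `CC(C)OC(=O)N1CCC(Oc2cccc3c2CCN3c2ccc(S(C)(=O)=O)cc2)CC1` gives 501 nM, compound 2 `CC(C)OC(=O)N1CCC(Oc2ncnc3c2CCN3c2ccc(S(C)(=O)=O)cc2)CC1` gives 126 nM, and compound 3 `CC(C)OC(=O)N1CCC(Oc2ncnc3c2CCN3c2ccc(-c3cccn3C)cc2F)CC1` gives 158 nM. Compound 2 has the lowest of the three numbers; its gap to compound 3 lies within the scatter of repeated measurements, while its gap to compound 1 lies beyond it. Compound 4 `CC(C)OC(=O)N1CCC(Oc2ncnc3c2CCN3c2ccc(S(C)(=O)=O)nc2)CC1` has not yet been measured. It differs from compound 2 in one place: 6-(methylsulfonyl)pyridin-3-yl in place of 4-(methylsulfonyl)phenyl on a nitrogen on an aromatic ring in a ring. Going by the values given here, no measured pair shows this change, so the expectation rests on compound 2 alone. Because compound 2 gives 126 nM, the step is expected to be a 1.3-fold higher number from compound 2 to compound 4 (0.10 log units; within the scatter), staying within the usual scatter. Compound 4 is therefore estimated to give about 160 nM, in a range from 50 nM to 500 nM.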

Compound 4, half-maximal effective concentration: 251 nM
The estimate for compound 4 lay 1.6-fold (0.20 log units) below the measured number, and the stated range covers the measured number.
By their numbers in this assay, from the lowest: compounds 2, 3, 4 and 1 (each within the scatter of the next, the first and the last beyond it).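

Swapping 4-(methylsulfonyl)phenyl for 6-(methylsulfonyl)pyridin-3-yl on the nitrogen of the five-membered non-aromatic ring gives, in this assay, a 2.0-fold higher number from compound 2 to compound 4 (0.30 log units; within the scatter), so this place accepts a ring nitrogen in the aromatic ring without a change beyond the scatter. The earlier compounds shown here held no pair differing in this place alone. No measurement at hand offers an explanation for this step.

Still open, going by these compounds, is how a nitrile or a carboxylic acid would fare in place of the methylsulfonyl group on this pyridine ring. A pyrimidine ring in this place also remains untested among the compounds shown.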